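Chloro for Fluoro on a Fused Ring

A few compounds are considered here, and "the series" means these few. Any claim that something is new, unique, unknown or untested is made for them only; others in the source may bear on it.

Three closely related compounds were measured in an assay on cell membranes for displacement of a labelled ligand from metabotropic glutamate receptor 5 (Rattus norvegicus), with a stated time of 60 min, tested at 1 uM; on this read-out lower numbers stand for less inhibition and higher numbers for more inhibition at the one concentration tested (going by the name of the read-out). Compound 1 `O=S(=O)(c1ccc(F)cc1)c1cnc2ccc(F)cc2c1-c1ccc(Cl)cc1` gives 76.3%. Compound 2 `O=S(=O)(c1ccc(F)cc1)c1cnc2cc(F)ccc2c1-c1ccc(Cl)cc1` is built from the same atoms as compound 1, joined differently; the difference between the two cores is not broken down here. In this assay compound 2 gives 91.6%, the highest of the three numbers, with compound 1 its nearest neighbour and compound 3 furthest away. Compound 3 `O=S(=O)(c1ccc(F)cc1)c1cnc2ccc(Cl)cc2c1-c1ccc(Cl)cc1` carries the change chloro in place of fluoro on an aromatic carbon relative to compound 1, and in this assay compound 3 gives 58.3%. That single exchange made a step of a number 18 percentage points lower from compound 1 to compound 3 (beyond the scatter).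

Compound 4 `O=S(=O)(c1ccc(F)cc1)c1cnc2cc(Cl)ccc2c1-c1ccc(Cl)cc1` has not yet been measured. It stands to compound 2 as compound 3 stands to compound 1: the change is chloro in place of fluoro on an aromatic carbon, the same change at the same kind of place on the fused ring. For the measured compounds named here, the only guide is the one earlier step, a number 18 percentage points lower from compound 1 to compound 3 (beyond the scatter), and whether the exchange behaves alike on the differently joined core of compound 2 cannot be read from these three compounds alone. A drop of similar size is therefore expected from compound 2 to compound 4, a number 17.6 percentage points lower from compound 2 to compound 4 (beyond the scatter), resting on the earlier step of a number 18 percentage points lower from compound 1 to compound 3 (beyond the scatter). Compound 4 is accordingly estimated at 74% in this assay, with a plausible range from 58% to 88%.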

Compound 4, a percentage reported as inhibition, at one concentration (the size of the read-out at that concentration, not a potency): 92.8%
Estimate against measurement, compound 4: 18.8 percentage points below, and the stated range ends below it.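

On the second core the picture differs from the first. In this assay, chloro in place of fluoro on an aromatic carbon gives a number 1.2 percentage points higher from compound 2 to compound 4 (within the scatter), so the exchange that lowered the number on the core of compound 1 leaves it within the scatter on the core of compound 2. The change therefore did not carry over in size from one core to the other, and its step on one core was a poor guide to its step on the other: the same change on two cores in this assay, a number 18 percentage points lower (beyond the scatter) from compound 1 to compound 3 and a number 1.2 percentage points higher (within the scatter) from compound 2 to compound 4, 19.2 percentage points apart, beyond the scatter of two such steps

This rests on a single pair on each core, read at one concentration, so it does not show why the two cores part ways, how the exchange would behave on any further core, or whether compound 2 and compound 4 would also match in potency.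

The compounds shown leave open whether a methyl, a methoxy or a nitrile in the place of the halogen would track the fluoro or the chloro result on either core. Going by these compounds, all of them also keep the same fluorophenyl sulfonyl and chlorophenyl groups, so how the difference between the cores would hold up with an amine or a longer chain on those parts remains unknown.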